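Furan-2-yl for 1H-imidazol-2-yl in the series

A few compounds are considered here, and "the series" means these few. Any claim that something is new, unique, unknown or untested is made for them only; others in the source may bear on it.

In a functional assay on NCI-H460 cells (Homo sapiens) for cytotoxicity, read by MTT assay, with a stated time of 72 h (on this read-out lower numbers stand for stronger inhibition and higher numbers for weaker inhibition), compound 1 `O=c1[nH]/c(=C\c2c[nH]cn2)c(=O)[nH]/c1=C\c1cccc(Oc2ccc(F)cc2)c1` gives 479 nM. Compound 2 `O=c1[nH]/c(=C\c2ncc[nH]2)c(=O)[nH]/c1=C\c1cccc(Oc2ccc(F)cc2)c1` gives > 1000 nM, which is a limit and not a number, and it stands at the limit of > 1000 nM in this assay, at which 1 of the 2 values shown sits. Compound 3 `O=c1[nH]/c(=C\c2ccco2)c(=O)[nH]/c1=C\c1cccc(Oc2ccc(F)cc2)c1` has furan-2-yl in place of 1H-imidazol-2-yl on a double-bonded chain carbon bound to an aromatic carbon. For the measured compounds named here, one measured step bears on this place: an at least 2.0-fold higher number from compound 1 to compound 2 (0.31 log units; beyond the scatter), at least modest, with its full size left open. A small move to a lower number is expected, an at least 1.2-fold lower number from compound 2 to compound 3 (0.09 log units; that floor lies within the scatter), and a result at the limit remains possible. For compound 3 the estimate is 800 nM, with an expected range of 250 nM to 2500 nM.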

Compound 3, half-maximal inhibitory concentration: 155 nM
For compound 3 the middle estimate is 5.2-fold (0.71 log units) above the measured one; measured number below the stated range.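

In this assay, furan-2-yl gives the lowest number of the three at this place, with an at least 6.4-fold lower number from compound 2 to compound 3 (0.80 log units; beyond the scatter) and a 3.1-fold lower number from compound 1 to compound 3 (0.49 log units; beyond the scatter). Compound 3 carries no hydrogen-bond donor on this ring, so a donor on the ring is not required for this level of cytotoxicity. The full size of the change from compound 2 stays open because that compound stands at a limit: the limit of > 1000 nM in this assay, at which 1 of the 3 values shown sits.

The compounds shown do not separate the gain of the ring oxygen from the loss of the ring nitrogens. A thiophen-2-yl or phenyl group at this place would bear on that question.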